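Replacing the pendant phenyl by methyl in an imidazolylmethyl biphenyl

The source may hold more compounds than are shown below. What is called first, only, known or untested is meant among the compounds shown, and "the series" means these compounds.

Measured so far in an in vitro assay on V79MZ cells for inhibition of cytochrome P450 11B1, mitochondrial (Homo sapiens); on this read-out higher numbers stand for weaker inhibition and lower numbers for stronger inhibition:
compound 1 `c1ccc(-c2cccc(Cn3ccnc3)c2)cc1` gives 46 nM
compound 3 `c1ccc(-c2cc(Cn3ccnc3)cc(-c3ccccc3)c2)cc1` gives 128 nM
compound 2 `c1ccc(-c2ccccc2Cn2cnc3ccccc32)cc1` gives only a limit, > 1000 nM

Compound 1 holds the lowest of the two numbers reported in this assay. Its nearest neighbour is compound 3, and the step of a 2.8-fold higher number from compound 1 to compound 3 (0.44 log units; beyond the scatter) is the only one that can be traced to a single change. For the measured compounds named here, for compound 2 the result is a limit of the assay and not a number (the limit of > 1000 nM in this assay, at which 1 of the 3 values shown sits), so it offers no measurable step.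

Compound 4 `Cc1cccc(Cn2ccnc2)c1` differs from compound 1 in one place: methyl in place of phenyl on an aromatic carbon. Going by the values given here, no measured pair shows this exchange. The closest guidance is the step of a 2.8-fold higher number from compound 1 to compound 3 (0.44 log units; beyond the scatter), in which a phenyl was added and the number rose modestly; here a phenyl is taken away and a methyl put in, which is a change of a different kind, and its direction is not shown by any of the compounds measured. The shared core of compound 1 is kept intact.

On that basis a modest rise in the number is expected rather than a fall, with wide uncertainty. Compound 4 is estimated at 150 nM, with a range from 40 nM to 600 nM. The expected step is a 3.3-fold higher number from compound 1 to compound 4 (0.51 log units; beyond the scatter).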

Compound 4, half-maximal inhibitory concentration: 48 nM
Compound 4: middle estimate off by 3.1-fold (0.49 log units), on the high side; the range from low to high includes it.
By their numbers in this assay, from the lowest: compounds 1 and 4 (each within the scatter of the next); then compound 3. At a limit, above all of these: compound 2.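

In this assay, exchanging the phenyl on this aromatic carbon, meta to a (1H-imidazol-1-yl)methyl group, for methyl gives a 1.0-fold higher number from compound 1 to compound 4 (0.02 log units; within the scatter), so the two compounds cannot be told apart on this read-out. The earlier compounds shown here showed only what adding a phenyl to the core of compound 1 does, namely a 2.8-fold higher number from compound 1 to compound 3 (0.44 log units; beyond the scatter); this exchange shows that the phenyl of compound 1, with its 6 heavy atoms and its six-membered aromatic ring, can give way to a methyl of 1 heavy atom with no measurable consequence in this assay, so the pendant ring is not needed to reach a number of this order here. Nothing among the data at hand bears on why the two compounds read alike.

What the compounds shown leave open is whether this tolerance extends beyond methyl, since only two groups have been seen on this carbon, and neither a bare hydrogen nor a longer chain such as propyl stands among them. Nor do they show how a methoxy group, an amine or a carboxylic acid on the same carbon would read in this assay.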